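Moving the amino group on the outer ring

The source may hold more compounds than are shown below. What is called first, only, known or untested is meant among the compounds shown, and "the series" means these compounds.

Of the compounds shown here, two sharing one core have been tested in a functional assay on HT29-AK cells (Homo sapiens) for cytotoxicity, read by MTT assay, with a stated time of 48 h; a lower number here means a stronger inhibitor, a higher number a weaker inhibitor. Compound 1, with structure `Oc1cccc(Nc2nc(-c3cccc(F)c3)nc3ccc(F)cc23)c1`, carries a hydroxy group on its outer ring. In this assay compound 1 gives > 50000 nM, which is a limit of the assay rather than a number. Compound 2, with structure `Nc1cccc(Nc2nc(-c3cccc(F)c3)nc3ccc(F)cc23)c1`, carries an amino group where compound 1 has the hydroxy. In this assay compound 2 gives > 50000 nM, again only a limit. Among the compounds with values here, the single measured step, a step that the two limits leave unreadable from compound 1 to compound 2, cannot be read in size because the limit of > 50000 nM in this assay, at which 2 of the 2 values shown sit, holds for both values. Compound 3, with structure `Nc1ccccc1Nc1nc(-c2cccc(F)c2)nc2ccc(F)cc12`, has not been measured; it differs from compound 2 by 2-aminophenyl in place of 3-aminophenyl on a nitrogen on an aromatic ring. No measured step involves a rearrangement of this kind, so nothing shown speaks to its direction or size. The expected step of a number no higher from compound 2 to compound 3 (the limit leaves the size open) is therefore taken as no change beyond the scatter, with compound 3 most likely reported only as a limit as well. Compound 3 is expected to give about 50000 nM in this assay, within a range from 20000 nM to 100000 nM.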

Compound 3, half-maximal inhibitory concentration: > 50000 nM
Compound 3 was reported as a limit; the forecaster's own chance of this, stated with the estimate: 80%; the middle value sits exactly at the limit.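

In this assay compound 3 gives > 50000 nM, again a limit and not a number. The steps among compound 1, compound 2 and compound 3 therefore cannot be read in size: the limit of > 50000 nM in this assay, at which 3 of the 3 values shown sit.

The compounds shown leave open whether any group on the outer ring of the shared core would give a readable number in this assay.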